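The source may report more compounds than this note shows. Statements on the series, on what has been measured and on what is new or still open speak of the compounds shown alone.

Compound 1 `C=C1CC[C@@H]2[C@](C)(CO)[C@H](O)CC[C@@]2(C)[C@@H]1CCC1=CCOC1=O` is the only compound with a measured number shown here. In a functional assay on RAW264.7 cells (Mus musculus) for inhibition, read by Griess assay, with a stated time of 24 h (a higher number here means a weaker inhibitor, a lower number a stronger inhibitor), compound 1 gives 21000 nM. Compound 2 `C=C1[C@@H](CCC2=CCOC2=O)[C@]2(C)CC[C@@H](O)[C@@](C)(CO)[C@H]2C[C@@H]1O` carries a hydroxy in place of hydrogen on a saturated ring carbon. In this assay compound 2 reaches only a limit of the assay, > 100000 nM. The step of an at least 4.7-fold higher number from compound 1 to compound 2 (0.67 log units; beyond the scatter) shows the inhibition weakened by that change, and the size of that step rests on (the limit of > 100000 nM in this assay, at which 1 of the 2 values shown sits). Compound 3 `C=C1CC[C@@H]2[C@](C)(CO)[C@H](O)C[C@@H](O)[C@@]2(C)[C@@H]1CCC1=CCOC1=O` differs from compound 1 by hydroxy in place of hydrogen on a saturated ring carbon. The step from compound 1 to compound 2 is the only measured one that bears on this change, so a weakening of similar size is expected in this assay. The expected step is a 2.9-fold higher number from compound 1 to compound 3 (0.46 log units; beyond the scatter). Compound 3 is therefore estimated to give 60000 nM in this assay, with a range from 20000 nM to 150000 nM, and it may well reach only a limit.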

Compound 3, half-maximal inhibitory concentration: > 100000 nM
Compound 3: no number, only a limit; the forecaster's own chance of this, stated with the estimate: 40%; middle value at least 1.6-fold (0.22 log units) from the limit.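

In this assay compound 3 reaches only a limit, > 100000 nM. The step, an at least 4.7-fold higher number from compound 1 to compound 3 (0.67 log units; beyond the scatter), shows that a hydroxy on this ring carbon, next to the ring atom that bears a methyl group, also weakens inhibition, so the loss now appears at two different ring carbons of the core of compound 1. How large each loss really is remains unknown, and compound 2 and compound 3 cannot be ranked against each other, because both stop at the same limit: the limit of > 100000 nM in this assay, at which 2 of the 3 values shown sit.

The compounds shown leave open whether a methoxy group or a fluorine atom on this ring carbon would weaken inhibition as the hydroxy does. They also leave open whether replacing the hydroxymethyl group of compound 1 with an amine or a carboxylic acid would change its inhibition.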